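Replacing the 4-carboxyphenyl group of compound 2

The source may hold more compounds than are shown below. What is called first, only, known or untested is meant among the compounds shown, and "the series" means these compounds.

Of the compounds shown here, two have been measured so far in an ADME assay (liver, Mus musculus) for metabolic stability, using microsomes (a higher number here means that the compound lasts longer, a lower number that the compound disappears faster), and neither gives an exact half-life. Compound 1 (`Cc1nc2ccc(Cl)cn2c1C(=O)NCc1ccc(-c2ccccc2)cc1`) reads > 1 h as its result, which is a limit of the assay and not a number. Compound 2 (`CCc1nc2cc(Cl)ccn2c1C(=O)NCc1ccc(-c2ccc(C(=O)O)cc2)cc1`) reads > 2 h as its result, and this too is only a limit. Compound 3 (`CCc1nc2cc(Cl)ccn2c1C(=O)NCc1ccc(-n2cc3c(c2)CCCC3)cc1`) keeps the rest of compound 2 and changes one group: a group of 9 heavy atoms (8 carbon, 1 nitrogen; one five-membered aromatic ring with 1 hetero atom, one six-membered non-aromatic ring of carbon only) in place of a group of 9 heavy atoms (7 carbon, 2 oxygen; one six-membered aromatic ring of carbon only), on an aromatic carbon. The change sits on an aromatic carbon of a six-membered aromatic ring of carbon only, para to a large group. For the measured compounds named here, no measured pair shows what such a replacement does, so this is a judgement with wide uncertainty. A fall beyond the usual scatter is expected in this assay, estimated as an at least 3.3-fold lower number from compound 2 to compound 3 (0.52 log units; beyond the scatter). Compound 3 is expected to show a half-life of 0.6 h, with an estimated range from 0.15 h to 2 h.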

Compound 3, half-life: 1.04 h
For compound 3 the middle estimate is 1.7-fold (0.24 log units) below the measured one, within the range that was stated.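

In this assay compound 3 gives 1.04 h, the first reading among the compounds shown that is a number and not a limit. Putting a group with a five-membered aromatic ring and a six-membered non-aromatic ring in place of the 4-carboxyphenyl group gives an at least 1.9-fold lower number from compound 2 to compound 3 (0.28 log units; that floor lies within the scatter), so this position accepts a group without a hydrogen-bond donor and still gives a measurable half-life. That step is only a floor that lies within the usual scatter, and its true size stays unknown, because compound 2 sits at a limit and not at a number: the limit of > 2 h in this assay, at which 1 of the 3 values shown sits.

On these data alone, how far the half-life of compound 2 lies past its limit remains open. Also open, as far as these compounds go, is what an amine or a pyridine ring would do on this aromatic carbon.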